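A Bromo Swap on the Aryl Ring of Compound 2

The source may report more compounds than this note shows. Statements on the series, on what has been measured and on what is new or still open speak of the compounds shown alone.

Compound 1 `Cc1cccc(-n2cc(C(=O)O)c(=O)c3c(O)c(Cc4cccc(Cl)c4F)ccc32)c1`: 71600 nM
Compound 2 `Cc1ccc(-n2cc(C(=O)O)c(=O)c3c(O)c(Cc4cccc(Cl)c4F)ccc32)cc1`: 194000 nM
Compound 3 `O=C(O)c1cn(-c2ccc(Br)cc2)c2ccc(Cc3cccc(Cl)c3F)c(O)c2c1=O`: not yet measured

In an ADME assay on C8166 cells (Homo sapiens) for cytotoxicity, read by MTT assay (on this read-out lower numbers stand for higher toxicity in this test and higher numbers for lower toxicity in this test), compound 2 gives the higher of the two numbers, 194000 nM, and its nearest neighbour is compound 1 at 71600 nM. The next structure, compound 3, follows from bromo in place of methyl on an aromatic carbon, para to a large group. Among the compounds with values here, only one measured step bears on this change, a 2.7-fold higher number from compound 1 to compound 2 (0.43 log units; beyond the scatter), with 4-methylphenyl in place of 3-methylphenyl on an aromatic nitrogen. That step is modest, though beyond the scatter. Within the data shown here, it shows that a change on this aromatic ring can shift the number, but no measured compound carries bromo, so the data do not settle the direction. A step of similar modest size is therefore expected, leaning slightly toward a lower number. The expected change is a 1.8-fold lower number from compound 2 to compound 3 (0.25 log units; within the scatter). For compound 3 the estimated value in this assay is 110000 nM, with an expected range of 40000 nM to 300000 nM.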

Compound 3, half-maximal cytotoxic concentration: 85000 nM
For compound 3 the middle estimate is 1.3-fold (0.11 log units) above the measured one; the measured number falls inside the stated range.
By their numbers in this assay, from the lowest: compounds 1 and 3 (each within the scatter of the next); then compound 2.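

In this assay, within the data shown here, the earlier compounds only moved a methyl around the ring, whereas this result changes the group itself at the place para to a large group. The change gives a 2.3-fold lower number from compound 2 to compound 3 (0.36 log units; beyond the scatter) and so shows that the number responds to which group sits there, not only to where a methyl sits. The second step, a 1.2-fold higher number from compound 1 to compound 3 (0.07 log units; within the scatter) with 4-bromophenyl in place of 3-methylphenyl, leaves compound 1 and compound 3 within the scatter of each other, so that compound 2, with its 4-methylphenyl, alone stands apart among the three, at the higher number. Nothing measured here speaks to what lies behind either step.

With a single halogen in the series, the compounds leave open whether the lower number belongs to bromo in particular or would also come with fluoro, chloro, methoxy or an amine in place of the methyl of compound 2. They also leave open whether a plain phenyl on the aromatic nitrogen would sit with compound 2 or with compound 3, and so whether the 4-methylphenyl of compound 2 is the exception in this set.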